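A few compounds are considered here, and "the series" means these few. Any claim that something is new, unique, unknown or untested is made for them only; others in the source may bear on it.

Compound 3 `CCN(CC)c1ccc2cc(C(=O)c3ccc(N4CCN(S(=O)(=O)c5ccc(Br)c(F)c5)CC4)cc3)oc2c1` carries a (4-bromo-3-fluorophenyl)sulfonyl group on an amine nitrogen in a six-membered non-aromatic ring with 2 nitrogen. In a functional assay on SGC-7901 cells (Homo sapiens) for cytotoxicity, read by MTT assay, with a stated time of 48 h (on this read-out lower numbers stand for stronger inhibition and higher numbers for weaker inhibition), compound 3 gives > 40000 nM, which is a limit of the assay and not a number. Compound 1 `CCN(CC)c1ccc2cc(C(=O)c3ccc(N4CCN(S(=O)(=O)c5ccc(Br)cc5)CC4)cc3)oc2c1` gives > 40000 nM, also a limit. Compound 2 `CCN(CC)c1ccc2cc(C(=O)c3ccc(N4CCN(S(=O)(=O)c5ccc(F)cc5)CC4)cc3)oc2c1` gives > 40000 nM, again a limit. All three values rest at the limit of > 40000 nM in this assay, at which 3 of the 3 values shown sit, so the steps a step that the two limits leave unreadable from compound 1 to compound 2, a step that the two limits leave unreadable from compound 1 to compound 3 and a step that the two limits leave unreadable from compound 2 to compound 3 cannot be sized. Compound 4 `CCN(CC)c1ccc2cc(C(=O)c3ccc(N4CCN(C(C)=O)CC4)cc3)oc2c1` differs by acetyl in place of (4-bromo-3-fluorophenyl)sulfonyl on an amine nitrogen in a ring. For the measured compounds named here, no measured step touches this position, so no direction can be read from the data. Compound 4 is therefore expected to give about 40000 nM, between 8000 nM and 100000 nM. The expected step is a number no higher from compound 3 to compound 4 (the limit leaves the size open).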

Compound 4, half-maximal inhibitory concentration: 25600 nM
Estimate against measurement, compound 4: 1.6-fold (0.19 log units) above; measured number inside the range.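

In this assay, for the compounds shown here, putting acetyl on this ring nitrogen gives the only true number in the set, whereas the steps among the three sulfonyl compounds cannot be read. The change appears as an at least 1.5-fold lower number from compound 3 to compound 4 (0.19 log units; that floor lies within the scatter), as an at least 1.5-fold lower number from compound 2 to compound 4 (0.19 log units; that floor lies within the scatter) and as an at least 1.5-fold lower number from compound 1 to compound 4 (0.19 log units; that floor lies within the scatter). Each of these is only a floor, and the true size stays hidden, since the sulfonyl compounds all stop at a limit: the limit of > 40000 nM in this assay, at which 3 of the 4 values shown sit.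

The compounds shown leave open what a methylsulfonyl group, which keeps the sulfonyl but has no aromatic ring, would give on this nitrogen. On these data alone, a benzoyl group or a free ring amine is equally open.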